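A Chloro Group Moves Around the Benzyl Ring

The source may hold more compounds than are shown below. What is called first, only, known or untested is meant among the compounds shown, and "the series" means these compounds.

Compound 1, `CCCCc1[nH]c(=O)c(-c2nnc(Cc3ccc(Cl)cc3)o2)c(O)c1-c1c(OC)cccc1OC`, gives 22% in an ADME assay on microsomes from liver (Rattus norvegicus) for metabolic stability, read by mass spectrometry, using NADPH, with a stated time of 10 min; a higher number here means that more of the compound is left, a lower number that less of the compound is left.
Compound 2, `CCCCc1[nH]c(=O)c(-c2nnc(Cc3ccccc3)o2)c(O)c1-c1c(OC)cccc1OC`, gives 53% in this assay.

Compound 2 holds the higher of the two numbers, with compound 1 lying beyond the scatter below it. Compound 3, `CCCCc1[nH]c(=O)c(-c2nnc(Cc3ccccc3Cl)o2)c(O)c1-c1c(OC)cccc1OC`, differs from compound 2 by chloro in place of hydrogen on an aromatic carbon. Among the compounds with values here, the only measured step that bears on this is a number 31 percentage points higher from compound 1 to compound 2 (beyond the scatter), which runs in the other direction for a chloro on that ring. Its full size is not assumed to carry over, but for compound 3 a drop beyond the scatter is expected, estimated as a number 18 percentage points lower from compound 2 to compound 3 (beyond the scatter). Compound 3 is therefore expected to give 35%, within 15% to 58%, in this assay.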

Compound 3, percent of the compound remaining: 24%
Estimate against measurement, compound 3: 11 percentage points above, within the range that was stated.
By their numbers in this assay, from the lowest: compounds 1 and 3 (each within the scatter of the next); then compound 2.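

Chloro on the benzyl ring now goes with a lower number at a second place, ortho to a large group, in this assay (a number 29 percentage points lower from compound 2 to compound 3 (beyond the scatter)). Exchanging 4-chlorophenyl for 2-chlorophenyl changes nothing readable (a number 2 percentage points higher from compound 1 to compound 3 (within the scatter)), so among these compounds the presence of chloro matters and these two places do not differ. No measurement at hand explains this. From the compounds shown here alone, whether fluoro or a methyl group on this ring would go with the same loss stays open, and so does whether an amine there would reverse it.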